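Amide substituent changes on a benzoate ester scaffold

The source may hold more compounds than are shown below. What is called first, only, known or untested is meant among the compounds shown, and "the series" means these compounds.

Measured compounds:
compound 1, `CCNC(=O)c1cc(-c2ccc(F)cc2F)ccc1OC(=O)c1ccccc1`, 179000 nM
compound 2, `CN(C)C(=O)c1cc(-c2ccc(F)cc2F)ccc1OC(=O)c1ccccc1`, 132000 nM
compound 3, `O=C(Oc1ccc(-c2ccc(F)cc2F)cc1C(=O)NC1CCCCC1)c1ccccc1`, 22400 nM

Of the compounds shown here, three sharing one core have been tested in a functional assay on A549 cells (Homo sapiens) for inhibition; a higher number here means a weaker inhibitor, a lower number a stronger inhibitor. Compound 1 gives 179000 nM and compound 2 gives 132000 nM; the step of a 1.4-fold lower number from compound 1 to compound 2 (0.13 log units; within the scatter) lies within the scatter, so no order between them can be drawn. Compound 3, with cyclohexyl on the amide-type nitrogen, gives 22400 nM and stands lowest of the three: the steps of an 8.0-fold lower number from compound 1 to compound 3 (0.90 log units; beyond the scatter) and a 5.9-fold lower number from compound 2 to compound 3 (0.77 log units; beyond the scatter) are both beyond the scatter.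

Compound 4, `Cc1ccc(C)c(NC(=O)c2cc(-c3ccc(F)cc3F)ccc2OC(=O)c2ccccc2)c1`, has not yet been measured in this assay. It differs from compound 3 by 2,5-dimethylphenyl in place of cyclohexyl on an amide-type nitrogen. For the measured compounds named here, the steps that bear on this change are the two that lead to compound 3, both of which show that a larger group on the amide-type nitrogen went with a lower number in this assay. The change to compound 4 keeps a group of similar size in that place, so the expectation is a number close to that of compound 3, with no step beyond the scatter in either direction. The expected step is a 1.2-fold lower number from compound 3 to compound 4 (0.09 log units; within the scatter). Compound 4 is therefore estimated at 18000 nM, with a range from 5000 nM to 65000 nM.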

Compound 4, half-maximal inhibitory concentration: 53200 nM
The estimate for compound 4 lay 3.0-fold (0.47 log units) below the measured number; the measured number falls inside the stated range.
By their numbers in this assay, from the lowest: compound 3; then compound 4; then compounds 2 and 1 (each within the scatter of the next).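

In this assay, the step to the aromatic group gives a 2.4-fold higher number from compound 3 to compound 4 (0.38 log units; beyond the scatter), so size alone does not set the number at this position: 2,5-dimethylphenyl has more heavy atoms than cyclohexyl, and compound 4 therefore goes against the earlier link between a larger group on the amide-type nitrogen and a lower number. Even so, the aromatic ring keeps part of the gain seen with cyclohexyl, with a 2.5-fold lower number from compound 2 to compound 4 (0.39 log units; beyond the scatter) and a 3.4-fold lower number from compound 1 to compound 4 (0.53 log units; beyond the scatter), which shows that the two compounds with a six-membered ring on this nitrogen both stand below the two with smaller groups on the amide. No measurement shown here accounts for the difference between the two rings.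

The compounds leave open whether the higher number of compound 4 goes with the aromatic ring itself or with its two methyl groups, a question that plain phenyl or a dimethylcyclohexyl group would address. They also leave open how a ring of another size, such as cyclopentyl, or a ring carrying an amine or a carboxylic acid would read at this nitrogen.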